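From chloro to (pyridin-2-yl)methoxy on a shared core

This account rests on a few compounds, and the source may have more. Where it says the series, first, only, none or still open, it means among the compounds named here.

Measured so far in a physicochemical assay for lipophilicity, read by HPLC, at pH 7.4; a lower number here means a more polar compound, a higher number a more lipophilic compound:
compound 1 `COCCOc1cc2oc(=O)n(CCC(=O)O)c2cc1Cl` gives 0.88
compound 2 `Cc1ccc([C@@H](C)Oc2cc3oc(=O)n(CCC(=O)O)c3cc2Cl)nc1` gives 2.02
compound 3 `O=C(O)CCn1c(=O)oc2cc(Cl)c(Cl)cc21` gives 1.61

Compound 3 stands second highest of the three, with compound 2 higher and compound 1 lower, both gaps beyond the scatter. Compound 4 `O=C(O)CCn1c(=O)oc2cc(OCc3ccccn3)c(Cl)cc21` has (pyridin-2-yl)methoxy in place of chloro on an aromatic carbon and is otherwise the same. Going by the values given here, the one measured step that bears on this is a number 0.73 log units higher from compound 1 to compound 3 (beyond the scatter) on exchanging 2-methoxyethoxy for chloro, which, read backwards, suggests a fall on losing chloro. Yet compound 2, which also carries a pyridine-bearing group, reads 2.02 and so tempers that. In this assay a small fall is therefore expected, perhaps not beyond the scatter. The expected change is a number 0.21 log units lower from compound 3 to compound 4 (within the scatter) in this estimate. Compound 4 is expected at 1.4 within an estimated range of 1 to 1.8 here.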

Compound 4, distribution coefficient: 1.32
For compound 4 the middle estimate is 0.08 log units above the measured one; measured number inside the range.
By their numbers in this assay, from the lowest: compound 1; then compounds 4 and 3 (each within the scatter of the next); then compound 2.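

In this assay, the step of a number 0.29 log units lower from compound 3 to compound 4 (within the scatter) shows that this aromatic carbon can carry (pyridin-2-yl)methoxy, with its 8 heavy atoms and six-membered aromatic ring, in place of chloro without a change beyond the scatter. With the ether oxygen kept, pyridin-2-yl in place of methoxymethyl gives a number 0.44 log units higher from compound 1 to compound 4 (beyond the scatter), so the group on that oxygen does shift the reading. Nothing measured here explains either step. As far as these compounds go, how a saturated amine or a longer chain on that oxygen would read remains open.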